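This account rests on a few compounds, and the source may have more. Where it says the series, first, only, none or still open, it means among the compounds named here.

Of the compounds shown here, three sharing one core have been measured in an assay for inhibition of Dihydrofolate reductase (Homo sapiens); a higher number here means a more potent compound, by a factor of ten per unit of this negative logarithm, a lower number a less potent compound. Compound 1, `Sc1nc(S)c2cc(Sc3ccc4ccccc4c3)ccc2n1`, gives 5.05 in this assay, the lowest of the three numbers. Compound 2, `Nc1ncnc2ccc(S(=O)(=O)c3ccc4ccccc4c3)cc12`, gives 5.47 in this assay, a number above compound 1 by more than the usual scatter. Compound 3, `Nc1nc(S)c2cc(S(=O)(=O)c3ccc4ccccc4c3)ccc2n1`, gives 7.6 in this assay, the highest of the three and far beyond the scatter from compound 1. Compound 4, `Oc1nc(S)nc2ccc(Sc3ccc4ccccc4c3)cc12`, has not yet been measured. It differs from compound 1 in one place: hydroxy in place of sulfanyl on an aromatic carbon. For the measured compounds named here, no measured pair differs in exactly this way, so the size of the step cannot be read from the measured compounds; compound 1 already sits at the bottom of the three. A modest fall, a little beyond the scatter, is expected, so the estimated step is a number 0.35 log units lower from compound 1 to compound 4 (beyond the scatter). Compound 4 is therefore expected to give about 4.7 in this assay, with a likely range from 4 to 5.4.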

Compound 4, logarithm of the reciprocal of the active concentration, log(1/C): 5
For compound 4 the middle estimate is 0.30 log units below the measured one; low and high end bracket the measured number.
By their numbers in this assay, from the lowest: compounds 4 and 1 (each within the scatter of the next); then compound 2; then compound 3.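

Placing hydroxy in place of sulfanyl on this aromatic carbon, next to the ring nitrogen, gives a number 0.05 log units lower from compound 1 to compound 4 (within the scatter) in this assay and so leaves the two compounds indistinguishable in this assay. For the compounds shown here, this is the first single-place change that can be read on the shared core, and it shows that, in this pair, one sulfur can be exchanged for one oxygen here without a measurable consequence for the number. The swap also keeps the counts of hydrogen-bond donors and acceptors the same, and nothing available bears on why the two numbers agree.

Going by these compounds, whether a methoxy group, a carboxylic acid or a longer chain on this carbon would also keep the number in place remains open. So does whether the same swap would read alike on compounds that differ elsewhere on the core, since only this one pair shows it.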